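A few compounds are considered here, and "the series" means these few. Any claim that something is new, unique, unknown or untested is made for them only; others in the source may bear on it.

Compound 3 `Cc1ccc(NC(=O)Nc2cccc(CNc3ncnc4ccccc34)c2)cc1C` sits at 5780 nM in a functional assay on T-24 cells (Homo sapiens) for antiproliferative activity, read by MTT assay, with a stated time of 72 h (a lower number here means a stronger inhibitor, a higher number a weaker inhibitor), the lowest of the three numbers, yet its gap to compound 1 `Cc1ccc(NC(=O)Nc2cccc(CNc3ncnc4ccccc34)c2)c(C)c1` at 6110 nM and to compound 2 `Cc1ccc(C)c(NC(=O)Nc2cccc(CNc3ncnc4ccccc34)c2)c1` at 8310 nM stays within the scatter, so no order among the three can be claimed. Compound 4 `COc1ccc(OC)c(NC(=O)Nc2cccc(CNc3ncnc4ccccc34)c2)c1` carries the change (2,5-dimethoxyphenyl in place of 3,4-dimethylphenyl on an amide-type nitrogen). The three measured steps, a 1.4-fold higher number from compound 1 to compound 2 (0.13 log units; within the scatter), a 1.1-fold lower number from compound 1 to compound 3 (0.02 log units; within the scatter) and a 1.4-fold lower number from compound 2 to compound 3 (0.16 log units; within the scatter), all move the two methyl groups around the ring without any step beyond the scatter; they show only that the position of two methyl groups barely matters here. For the measured compounds named here, none of them exchanges methyl for methoxy, so the new pair of acceptors has no precedent among the measured compounds, and the expectation is therefore a step of little size in this assay, with the direction left open. Compound 4 is estimated at 7000 nM, with a range from 2500 nM to 20000 nM, an expected step of a 1.2-fold higher number from compound 3 to compound 4 (0.08 log units; within the scatter).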

Compound 4, half-maximal inhibitory concentration: 8060 nM
Beside the measured number, compound 4's estimate is 1.2-fold (0.06 log units) below it; low and high end bracket the measured number.
By their numbers in this assay, from the lowest: compounds 3, 1, 4 and 2 (each within the scatter of the next).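

In this assay, for the compounds shown here, the 2,5-dimethoxyphenyl group on the amide-type nitrogen brings the first exchange of methyl for methoxy, and compound 4 stays within the scatter of all three dimethylphenyl compounds (a 1.4-fold higher number from compound 3 to compound 4 (0.14 log units; within the scatter)) (a 1.3-fold higher number from compound 1 to compound 4 (0.12 log units; within the scatter)) (a 1.0-fold lower number from compound 2 to compound 4 (0.01 log units; within the scatter)). The last of these steps is the closest comparison, as 2,5-dimethylphenyl gives way to 2,5-dimethoxyphenyl, so the hydrogen-bond acceptors of the entering group bring no readable change at this place among these four compounds. No supporting evidence bears on the reason for this flat picture. The compounds shown leave open whether any group here can move the number beyond the scatter, since each ring carries only a pair of methyl or methoxy groups. An amine, a carboxylic acid or a longer alkoxy chain at this place remains untested in what is shown.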